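Trimethoxyphenyl replacement on the arylacrylic acid series

This account rests on a few compounds, and the source may have more. Where it says the series, first, only, none or still open, it means among the compounds named here.

Compound 2 `CC(=O)n1cc(/C=C(/C(=O)O)c2ccccc2)c2cc(OCc3ccccc3)ccc21` gives 26700 nM in a functional assay on DU-145 cells (Homo sapiens) for cytotoxicity, read by MTT assay, with a stated time of 72 h (on this read-out higher numbers stand for weaker inhibition and lower numbers for stronger inhibition), and stands second highest of the three numbers: its nearest neighbour is compound 3 `COc1ccc(/C(=C\c2c[nH]c3ccc(OCc4ccccc4)cc23)C(=O)O)cc1` with 38100 nM, a gap within the scatter, and its furthest is compound 1 `COc1cccc(/C(=C\c2cn(C(C)=O)c3ccc(OCc4ccccc4)cc23)C(=O)O)c1` with 1080 nM. Compound 3 differs from compound 2 in more than one place, so its value serves only as a second point at the weaker end. The step to compound 4 `COc1cc(/C(=C\c2cn(C(C)=O)c3ccc(OCc4ccccc4)cc23)C(=O)O)cc(OC)c1OC` is 3,4,5-trimethoxyphenyl in place of phenyl on a double-bonded chain carbon bound to a carbonyl carbon and a double-bonded chain carbon. For the measured compounds named here, one measured step bears on it: a 25-fold higher number from compound 1 to compound 2 (1.39 log units; beyond the scatter), which shows that removal of a single methoxy from this ring carries a large rise in the number. Going by the values given here, compound 4 puts three methoxy groups onto the same ring, so a step in the opposite direction, of at least comparable size, is expected in this assay, with the caveat that only one such step is on record and the three-substituent pattern is untested here. Compound 4 is therefore expected to reach 800 nM, with a range from 100 nM to 6000 nM, an expected step of a 33-fold lower number from compound 2 to compound 4 (1.52 log units; beyond the scatter).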

Compound 4, half-maximal inhibitory concentration: 950 nM
For compound 4 the middle estimate is 1.2-fold (0.07 log units) below the measured one; measured number inside the range.
By their numbers in this assay, from the lowest: compounds 4 and 1 (each within the scatter of the next); then compounds 2 and 3 (each within the scatter of the next).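

Notes on the group on the double-bonded chain carbon bound to a carbonyl carbon and a double-bonded chain carbon, in this assay: with 3,4,5-trimethoxyphenyl in place of phenyl, the result is a 28-fold lower number from compound 2 to compound 4 (1.45 log units; beyond the scatter), so a large step also appears with this three-methoxy ring and not only with the single methoxy of 3-methoxyphenyl. With 3,4,5-trimethoxyphenyl in place of 3-methoxyphenyl, the result is a 1.1-fold lower number from compound 1 to compound 4 (0.06 log units; within the scatter), so the two additional methoxy groups do not separate these two compounds, and among these three compounds only the unsubstituted phenyl of compound 2 stands apart. Nothing on hand accounts for either step. Going by these compounds, whether a hydroxyl or an amine on this ring in place of a methoxy keeps the number close to that of compound 1 stays open. On these data alone, compound 3 differs from the others in more than one place, so the contribution of its other features also stays open.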